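The source may report more compounds than this note shows. Statements on the series, on what has been measured and on what is new or still open speak of the compounds shown alone.

In a functional assay on BGC-823 cells (Homo sapiens) for inhibition, read by MTT assay, with a stated time of 72 h (a higher number here means a weaker inhibitor, a lower number a stronger inhibitor), the measured set reads:

compound 1 `Cc1cc(N2CC[C@@H](C)[C@@H](N(C)c3ncnc4[nH]ccc34)C2)n2ncnc2n1` — 67400 nM
compound 2 `Cc1cc(N2CC[C@@H](C)[C@@H](N(C)c3ncnc4[nH]ccc34)C2)n2nc(SCC3CCCCC3)nc2n1` — 16300 nM
compound 3 `Cc1cc(N2CC[C@@H](C)[C@@H](N(C)c3ncnc4[nH]ccc34)C2)n2nc(SCC3CC3)nc2n1` — 36500 nM

Compound 3 stands second highest of the three numbers in this assay: its nearest neighbour is compound 1, within the scatter, and its furthest is compound 2, beyond it. Compound 4 `COc1ccc(CSc2nc3nc(C)cc(N4CC[C@@H](C)[C@@H](N(C)c5ncnc6[nH]ccc56)C4)n3n2)cc1` differs from compound 3 by 4-methoxyphenyl in place of cyclopropyl on a saturated chain carbon bound to a sulfur. Going by the values given here, the steps that bear on this change are a 2.2-fold higher number from compound 2 to compound 3 (0.35 log units; beyond the scatter), a 4.1-fold lower number from compound 1 to compound 2 (0.62 log units; beyond the scatter) and a 1.8-fold lower number from compound 1 to compound 3 (0.27 log units; within the scatter); a substituent on the sulfur-bound carbon has so far lowered the number, most for cyclohexyl. A step of about the size of compound 2 over compound 1 is therefore expected, downward, a 2.4-fold lower number from compound 3 to compound 4 (0.39 log units; beyond the scatter). Compound 4 is estimated at 15000 nM, with a range of 5000 nM to 45000 nM.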

Compound 4, half-maximal inhibitory concentration: 69900 nM
Compound 4: middle estimate off by 4.7-fold (0.67 log units), on the low side; the measured number lies above the stated range.
By their numbers in this assay, from the lowest: compound 2; then compounds 3, 1 and 4 (each within the scatter of the next).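

In this assay the step of a 1.0-fold higher number from compound 1 to compound 4 (0.02 log units; within the scatter) and the step of a 1.9-fold higher number from compound 3 to compound 4 (0.28 log units; within the scatter) both lie within the scatter, so (4-methoxybenzyl)sulfanyl breaks the earlier reading that a substituent here lowers the number. Compound 2 now stands alone, with a 4.3-fold higher number from compound 2 to compound 4 (0.63 log units; beyond the scatter) beyond the scatter, and size alone does not order the series, since compound 4 carries the largest group entering at this place. Nothing measured here explains this.

Open, going by these compounds, is whether the methoxy group or the aromatic ring sets the result for compound 4. Unsubstituted benzyl and cyclopentylmethyl on the sulfur would separate these.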